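Swapping the outer aryl ring on a fatty acid receptor agonist

The source may report more compounds than this note shows. Statements on the series, on what has been measured and on what is new or still open speak of the compounds shown alone.

Two compounds share a core built from an acid side chain and an ether-linked biaryl arm. Compound 1 `Cn1ccnc1[C@@H](CC(=O)O)c1ccc(OCc2cccc(-c3ccccc3S(C)(=O)=O)c2)cc1` carries a methylsulfonyl-bearing phenyl ring at the far end; in an assay on CHO cells for agonist activity at Free fatty acid receptor 1 (Homo sapiens), read by luminescence, with a stated time of 20 s, in the presence of a further agent that is not named here (on this read-out higher numbers stand for an effect only at larger amounts of compound and lower numbers for an effect already at smaller amounts), the read-out for compound 1 is "not determined" (no result reported), so it gives no number to lean on. Within the data shown here, compound 2 `Cc1cc(Cl)ccc1-c1cccc(COc2ccc([C@H](CC(=O)O)c3nccn3C)cc2)c1` is the only compound with a reported figure: in this assay compound 2 gives 10000 nM, a weak result that stands alone, with nothing else measured to rank it against. Compound 3 `Cn1ccnc1[C@@H](CC(=O)O)c1ccc(OCc2cccc(-c3ccccc3Cl)c2)cc1` differs from compound 2 in one place, (2-chlorophenyl in place of 4-chloro-2-methylphenyl on an aromatic carbon). Among the measured compounds shown here, no measured pair shows how such a swap plays out here, so the direction can only be guessed. The step from compound 2 to compound 3 is expected to be modest, a 1.7-fold lower number from compound 2 to compound 3 (0.22 log units; within the scatter), with weak potency kept. Compound 3 is estimated at 6000 nM, within a range from 1500 nM to 20000 nM.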

Compound 3, half-maximal effective concentration: 56000 nM
Beside the measured number, compound 3's estimate is 9.3-fold (0.97 log units) below it; measured number outside the range, above it.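

This position is sensitive to the outer ring: in this assay, changing to 2-chlorophenyl gives a 5.6-fold higher number from compound 2 to compound 3 (0.75 log units; beyond the scatter). The change therefore runs towards needing more compound for an effect, starting from a compound that was already weak. Nothing available here explains why the number rises.

4-Chloro-2-methylphenyl and 2-chlorophenyl differ both in the methyl group and in where the chlorine sits, so this one step cannot separate the two changes, and compound 1 gives "not determined" (no result reported), so its methylsulfonyl-bearing ring adds no comparison. Also open, going by these compounds, is how an outer ring carrying a different group, such as a methoxy group or an amine, would fare at this position.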